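The source may report more compounds than this note shows. Statements on the series, on what has been measured and on what is new or still open speak of the compounds shown alone.

Measured compounds:
- compound 1, `Cc1ccc2ncc(S(=O)(=O)c3ccc(C)c(Cl)c3)c(N3CCC(C)CC3)c2c1`, gives 91%
- compound 2, `Cc1ccc2ncc(S(=O)(=O)c3ccc(C#N)cc3)c(N3CCC(C)CC3)c2c1`, gives 55%
- compound 3, `Cc1ccc(S(=O)(=O)c2cnc3ccc(C)cc3c2N2CCC(C)CC2)cc1`, gives 82%

These three compounds share one core and were tested in an assay on isolated protein for displacement of a labelled ligand from metabotropic glutamate receptor 5 (Homo sapiens), with a stated time of 60 min, tested at 1 uM; on this read-out lower numbers stand for less inhibition and higher numbers for more inhibition at the one concentration tested (going by the name of the read-out). Compound 1 stands at the top of the three numbers, but only its gap to compound 2 is beyond the scatter: the step of a number 36 percentage points lower from compound 1 to compound 2 (beyond the scatter) is large, whereas the step of a number 9 percentage points lower from compound 1 to compound 3 (within the scatter) is within the scatter, so compound 1 and compound 3 cannot be told apart. Between compound 2 and compound 3 the step of a number 27 percentage points higher from compound 2 to compound 3 (beyond the scatter) is modest.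

Compound 4, `Cc1ccc(S(=O)(=O)c2cnc3ccc(Cl)cc3c2N2CCC(C)CC2)cc1Cl`, has not yet been measured in this assay. It differs from compound 1 by chloro in place of methyl on an aromatic carbon. Going by the values given here, all three measured steps concern the aryl group on the sulfonyl sulfur; none touches the ring of the shared core where this change sits, so no measured step bears directly on it. With nothing to point to a change, the expected step of a number 4 percentage points lower from compound 1 to compound 4 (within the scatter) is none beyond the scatter, and the estimate rests on the value of compound 1 alone. Compound 4 is therefore expected to give 87%, with a range from 70% to 98%.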

Compound 4, a percentage reported as inhibition, at one concentration (the size of the read-out at that concentration, not a potency): 81%
For compound 4 the middle estimate is 6 percentage points above the measured one; the measured number falls inside the stated range.
By their numbers in this assay, from the lowest: compound 2; then compounds 4, 3 and 1 (each within the scatter of the next).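

In this assay, going by these compounds alone, the step of a number 10 percentage points lower from compound 1 to compound 4 (within the scatter) is the first measured change on the ring of the shared core, since all the earlier steps concerned the aryl group on the sulfonyl sulfur. It shows that, at the one concentration tested, methyl and chloro on this aromatic carbon cannot be told apart, so this single exchange on the core leaves the read-out within the usual scatter. The data hold nothing that would explain this result.

This single exchange says nothing about how other groups would fare on the same aromatic carbon, such as a methoxy group, an amine or a carboxylic acid, or whether chloro there would give the same result with the 4-cyanophenyl group of compound 2 on the sulfonyl sulfur. On these data alone, because each number is a percentage at one concentration and not a potency, it also remains open whether compound 1 and compound 4 would still be indistinguishable in a full concentration series.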